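Stretching the Chain Further in a Flat Series

The source may hold more compounds than are shown below. What is called first, only, known or untested is meant among the compounds shown, and "the series" means these compounds.

Measured so far in a functional assay, read by spectrophotometry, with a stated time of 6 min (a lower number here means a stronger inhibitor, a higher number a weaker inhibitor), for three compounds:
Compound 1 (`COc1cc(O)c(C(C)=O)cc1Br`): 31400000 nM
Compound 2 (`CCOc1cc(OC)c(Br)cc1C(C)=O`): 36000000 nM
Compound 3 (`CCCCCCCCOc1cc(OC)c(Br)cc1C(C)=O`): 32000000 nM

Compound 4 (`CCCCCCCCCCCCCCCCOc1cc(OC)c(Br)cc1C(C)=O`) has not yet been measured. Compound 3 gives 32000000 nM and sits among three numbers that all lie within the scatter of one another, so no order among them can be read. The change leading to compound 4 is octyl in place of hydrogen on a saturated chain carbon, eight bonds along the chain from an oxygen on an aromatic ring and it makes the chain of compound 3 longer still. Two earlier steps bear on this: a 1.1-fold higher number from compound 1 to compound 2 (0.06 log units; within the scatter) with ethyl in place of hydrogen on an oxygen on an aromatic ring, and a 1.1-fold lower number from compound 2 to compound 3 (0.05 log units; within the scatter) with hexyl in place of hydrogen on a saturated chain carbon. Both lie within the scatter, so neither shows a direction. No step beyond the scatter is expected in this assay for the added octyl, although no chain this long has been measured. The estimated step is a 1.0-fold lower number from compound 3 to compound 4 (0.01 log units; within the scatter) and so stays within the scatter. For compound 4 the expected value is 31000000 nM with an estimated range of 15000000 nM as the lower end and 60000000 nM as the upper end.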

Compound 4, half-maximal inhibitory concentration: 4600000 nM
Estimate against measurement, compound 4: 6.7-fold (0.83 log units) above, and the stated range ends above it.
By their numbers in this assay, from the lowest: compound 4; then compounds 1, 3 and 2 (each within the scatter of the next).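

In this assay, octyl in place of hydrogen on a saturated chain carbon, eight bonds along the chain from an oxygen on an aromatic ring, gives a 7.0-fold lower number from compound 3 to compound 4 (0.84 log units; beyond the scatter). Going by these compounds alone, the earlier lengthening, a 1.1-fold lower number from compound 2 to compound 3 (0.05 log units; within the scatter), stayed within the scatter, so this is the first step to move the number beyond it, and the flat picture does not hold for every chain length. Nothing available here explains why this added length changes the number.

On these data alone, it remains open whether the number falls gradually with length or changes abruptly somewhere between the chains of compound 3 and compound 4. Also open, as far as these compounds go, is whether a still longer chain, or a chain ending in an amine or a carboxylic acid, would lower the number further.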